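One Fluorine at a New Place on Compound 2

The source may report more compounds than this note shows. Statements on the series, on what has been measured and on what is new or still open speak of the compounds shown alone.

Measured so far:
- Compound 1 `Cc1ccc(/C=C2\Cc3ccccc3C2=O)cc1`: in a functional assay on MOLT-4 cells (Homo sapiens) for inhibition (on this read-out lower numbers stand for stronger inhibition and higher numbers for weaker inhibition), compound 1 gives only the assay limit > 500000 nM.
- Compound 2 `O=C1/C(=C/c2ccccc2)CCc2ccccc21`: compound 2 gives 32400 nM.
- Compound 3 `O=C1/C(=C/c2cccc(F)c2)CCc2ccccc21`: compound 3 gives 11900 nM.

Among the two real numbers, compound 2 stands highest, that is, it is the weaker inhibitor; its nearest neighbour is compound 3, and the step of a 2.7-fold lower number from compound 2 to compound 3 (0.43 log units; beyond the scatter) is the only one beyond the scatter here. Compound 1 sits at a limit (the limit of > 500000 nM in this assay, at which 1 of the 3 values shown sits), so it gives no number to compare.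

Compound 4 `O=C1/C(=C/c2ccc(F)cc2)CCc2ccccc21` is not yet measured. It differs from compound 2 by fluoro in place of hydrogen on an aromatic carbon.

Going by the values given here, the one measured step that bears on this is the same exchange of hydrogen for fluoro on the same six-membered aromatic ring of carbon only, though at another carbon: a 2.7-fold lower number from compound 2 to compound 3 (0.43 log units; beyond the scatter), a modest lowering. Nothing further among these compounds tells whether the position matters. A lowering of similar, perhaps slightly smaller size is therefore expected for a 1.8-fold lower number from compound 2 to compound 4 (0.26 log units; within the scatter).

Compound 4 is thus estimated at 18000 nM, with a range from 7000 nM to 45000 nM.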

Compound 4, half-maximal inhibitory concentration: 41200 nM
For compound 4 the middle estimate is 2.3-fold (0.36 log units) below the measured one, and the stated range covers the measured number.
By their numbers in this assay, from the lowest: compound 3; then compounds 2 and 4 (each within the scatter of the next). At a limit, above all of these: compound 1.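

In this assay, the step of a 1.3-fold higher number from compound 2 to compound 4 (0.10 log units; within the scatter) shows that fluoro in place of hydrogen at the carbon para to a large group brings no change that can be told from the scatter. The same exchange at another carbon of the ring did move the number beyond the scatter (a 2.7-fold lower number from compound 2 to compound 3 (0.43 log units; beyond the scatter)), so among these compounds a fluoro on this ring does not lower the number wherever it sits, and the earlier pair alone could not show this dependence on place. No measurement among those shown explains why the two carbons differ, and the limit reached by compound 1 has no bearing on this comparison.

On these data alone, it remains open whether a group other than fluoro at this same carbon, such as chloro, methoxy, an amine or a carboxylic acid, would shift the number in either direction. As far as these compounds go, it is equally open whether those groups, or a longer chain, would do more at the carbon that carries the fluoro in compound 3, and whether the remaining carbons of the ring behave like either of these two.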